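Two Measured Amides and an Unmeasured Diacid Analogue

This account rests on a few compounds, and the source may have more. Where it says the series, first, only, none or still open, it means among the compounds named here.

Measured compounds:
compound 1, `CCn1c(C(=O)N[C@H](CO)C(C)C)ccc1C(CC)(CC)c1ccc(OCS(=O)(=O)c2ccccc2)c(C)c1`, 7720 nM
compound 2, `CCn1c(C(=O)N[C@H](CO)CCO)ccc1C(CC)(CC)c1ccc(OCS(=O)(=O)c2ccccc2)c(C)c1`, 15900 nM

In a functional assay on BXPC-3 cells (Homo sapiens) for antiproliferative activity, read by MTT assay, with a stated time of 24 h (on this read-out lower numbers stand for stronger inhibition and higher numbers for weaker inhibition), compound 2 gives 15900 nM, the highest of the two numbers; its nearest neighbour is compound 1, which gives 7720 nM in this assay. Among the measured compounds shown here, the single measured step, a 2.1-fold higher number from compound 1 to compound 2 (0.31 log units; beyond the scatter), is modest but lies beyond the scatter.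

Compound 3, `CCn1c(C(=O)N[C@H](CCC(=O)O)C(=O)O)ccc1C(CC)(CC)c1ccc(OCS(=O)(=O)c2ccccc2)c(C)c1`, has not yet been measured. Its difference from compound 2 is 1,3-dicarboxypropyl in place of 3-hydroxy-1-(hydroxymethyl)propyl on an amide-type nitrogen. For the measured compounds named here, no measured step covers this change: the only step available swaps one chain carbon substituent for another on the same shared core, and it does not involve a carboxylic acid. Going by the values given here, the step from compound 1 to compound 2 offers the sole guide, and it shows that the two chains differ modestly. On that basis compound 3 is expected to land close to compound 2, with the step of a 1.6-fold higher number from compound 2 to compound 3 (0.20 log units; within the scatter) judged likely to fall near or just beyond the scatter and probably toward a higher number. The estimate for compound 3 in this assay is 25000 nM, within a range from 8000 nM to 80000 nM.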

Compound 3, half-maximal inhibitory concentration: > 50000 nM
Compound 3 gave a limit, no number (the forecaster's own chance of this, stated with the estimate: 20%); middle value at least 2.0-fold (0.30 log units) away from the limit.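

In this assay compound 3 gives only a limit of the assay, not a number: the limit of > 50000 nM in this assay, at which 1 of the 3 values shown sits.

Even so, the direction and a minimum size can be read: 1,3-dicarboxypropyl on the amide-type nitrogen gives an at least 3.1-fold higher number from compound 2 to compound 3 (0.49 log units; beyond the scatter), and against the isopropyl-bearing chain of compound 1 it gives an at least 6.4-fold higher number from compound 1 to compound 3 (0.81 log units; beyond the scatter). The earlier pair showed only a change between two chains that both keep a hydroxymethyl group and carry no carboxylic acid, whereas these steps show that a chain with two carboxylic acid groups at this place goes with weaker inhibition than either hydroxyl-bearing chain, beyond the scatter in both cases.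

The compounds shown leave open how large the loss really is, since both steps rest on a limit, and whether it follows from the carboxylic acid on the chain carbon bound to the nitrogen, from the one at the end of the chain, or from the two together. They also leave open whether a chain with a single carboxylic acid, a methyl ester in place of each acid, or a primary amine at the chain end would read closer to compound 1 or to compound 3.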